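The source may hold more compounds than are shown below. What is called first, only, known or untested is meant among the compounds shown, and "the series" means these compounds.

Measured so far in an assay on HEK-293T cells for activation of Bile acid receptor (Homo sapiens), read by a luciferase reporter, with a stated time of 14 h; a higher number here means that more compound is needed for the effect, a lower number that less compound is needed:
compound 1 `CC(C)c1onc(-c2c(Cl)cccc2Cl)c1COc1ccc(CCCC(=O)O)cc1`: 6000 nM
compound 2 `CC(C)c1onc(-c2ccccc2)c1COc1ccc(COc2ccc(CC(=O)O)cc2)cc1`: 11000 nM

Compound 2 stands highest of the two numbers; its nearest neighbour is compound 1, and the gap between the two values lies within the usual scatter, so the two cannot be ordered. For the measured compounds named here, the two compounds differ in more than one place, and no single step connects them.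

Compound 3 `CC(C)c1onc(-c2c(Cl)cccc2Cl)c1COc1ccc(COc2ccc(CC(=O)O)cc2)cc1` has not yet been measured. It differs from compound 2 by one change: 2,6-dichlorophenyl in place of phenyl on an aromatic carbon. Compound 3 thus carries the same 2,6-dichlorophenyl as compound 1 together with the tail of compound 2. Going by the values given here, this change has not been tested on its own, and the only comparison available, compound 1 against compound 2, is within the scatter. For compound 3 the expected step from compound 2 to compound 3 is therefore small, a 1.8-fold lower number from compound 2 to compound 3 (0.26 log units; within the scatter), with a slight lean toward a lower number. Compound 3 is expected to give 6000 nM in this assay, within a range from 2000 nM to 18000 nM.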

Compound 3, half-maximal effective concentration: 2000 nM
Beside the measured number, compound 3's estimate is 3.0-fold (0.48 log units) above it; measured number inside the range.
By their numbers in this assay, from the lowest: compound 3; then compounds 1 and 2 (each within the scatter of the next).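

In this assay, for the compounds shown here, 2,6-dichlorophenyl in place of phenyl on the aromatic carbon next to the ring nitrogen gives a 5.5-fold lower number from compound 2 to compound 3 (0.74 log units; beyond the scatter) and so provides the first single-change reading at this position. With 2,6-dichlorophenyl held constant, 4-(carboxymethyl)phenoxy in place of 2-carboxyethyl on the saturated chain carbon bound to an aromatic carbon gives a 3.0-fold lower number from compound 1 to compound 3 (0.48 log units; beyond the scatter) and shows that the number also responds to a change in the tail. No supporting data bear on the cause of either step.

Open, from the compounds shown here alone, is whether a single chlorine, or two methyl or two trifluoromethyl groups in place of the two chlorines, would give a step of similar size. Also open, going by these compounds, is whether a tetrazole or an amide could stand in place of the carboxylic acid on the tail of compound 3.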